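From hydroxy to ethoxycarbonyl in compound 3

The compounds below may be only part of what the source reports. "The series", "measured", "known", "first", "only" and "open" are said of these compounds alone.

Of the compounds shown here, three have been measured so far in a functional assay on U-87MG ATCC cells (Homo sapiens) for cytotoxicity, read by resazurin assay, with a stated time of 48 h; on this read-out higher numbers stand for weaker inhibition and lower numbers for stronger inhibition. Compound 1 `O=C1/C(=C/c2ccc(F)cc2)CS(=O)(=O)C/C1=C\c1ccc(F)cc1` gives 2210 nM. Compound 2 `O=C1/C(=C/c2ccc([N+](=O)[O-])cc2)CCC/C1=C\c1ccc([N+](=O)[O-])cc1` gives 27500 nM. Compound 3 `O=C1/C(=C/c2ccc([N+](=O)[O-])cc2)CC(O)C/C1=C\c1ccc([N+](=O)[O-])cc1` gives 4620 nM, the second highest of the three numbers, lying under that of compound 2 and over that of compound 1.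

Compound 4 `CCOC(=O)C1C/C(=C\c2ccc([N+](=O)[O-])cc2)C(=O)/C(=C/c2ccc([N+](=O)[O-])cc2)C1` has yet to be measured in this assay. It differs from compound 3 by ethoxycarbonyl in place of hydroxy on a saturated ring carbon, with ethoxycarbonyl in place of hydroxy on a saturated ring carbon. Within the data shown here, the one measured step that bears on this change is a 6.0-fold lower number from compound 2 to compound 3 (0.77 log units; beyond the scatter), which came with hydroxy in place of hydrogen on a saturated ring carbon. Among the measured compounds shown here, that modest step suggests that losing the hydroxy could give part of it back, but no measured compound carries ethoxycarbonyl, so the expectation is weak. The expected step is a 1.5-fold higher number from compound 3 to compound 4 (0.18 log units; within the scatter), leaning towards a higher number without a clear move beyond the scatter. Compound 4 is estimated at 7000 nM, within an expected range of 2500 nM to 20000 nM.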

Compound 4, half-maximal inhibitory concentration: 2470 nM
Estimate against measurement, compound 4: 2.8-fold (0.45 log units) above, and the stated range ends above it.
By their numbers in this assay, from the lowest: compounds 1, 4 and 3 (each within the scatter of the next, the first and the last beyond it); then compound 2.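

In this assay, this saturated ring carbon carries ethoxycarbonyl as readily as hydroxy: the exchange gives a 1.9-fold lower number from compound 3 to compound 4 (0.27 log units; within the scatter) and so does not separate the two groups, even though ethoxycarbonyl has no hydrogen-bond donor. Measured against the hydrogen of the unsubstituted ring, ethoxycarbonyl gives an 11-fold lower number from compound 2 to compound 4 (1.05 log units; beyond the scatter) and thus extends the earlier result of a 6.0-fold lower number from compound 2 to compound 3 (0.77 log units; beyond the scatter) to a second group, showing that, in these compounds, the lower number at this place does not require a hydrogen-bond donor. Nothing available here explains why either group lowers the number.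

The compounds shown leave open whether a carboxylic acid or an amine on this carbon would match ethoxycarbonyl. They also leave open whether an ester with a longer chain would keep the number this low.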